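The source may hold more compounds than are shown below. What is called first, only, known or untested is meant among the compounds shown, and "the series" means these compounds.

Measured so far in a functional assay on MCF7 cells (Homo sapiens) for cytotoxicity, read by MTT assay, with a stated time of 24 h; a higher number here means a weaker inhibitor, a lower number a stronger inhibitor:

compound 1 `O=C(NC(=S)Nc1nc2ccccc2s1)c1ccc([N+](=O)[O-])cc1` — 33800 nM
compound 2 `CCCCC(=O)NC(=S)Nc1nc2cc(N)ccc2s1` — 44700 nM
compound 3 `O=C(NC(=S)Nc1nc2cc([N+](=O)[O-])ccc2s1)c1ccccc1` — 41600 nM

All three share an acylthiourea attached to the same core. Compound 2 sits at the upper end of the three numbers, but its gap to compound 3 and its gap to compound 1 both lie within the usual scatter of this assay, so the three compounds cannot be separated on these data. Going by the values given here, no pairwise step between measured compounds is available, and no measured pair differs in only one place, so there is no reference step in this assay for the change considered here.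

Compound 4 `Nc1ccc2sc(NC(=S)NC(=O)c3ccccc3)nc2c1` is not yet measured in this assay. It differs from compound 2 as follows:

phenyl in place of butyl on a carbonyl carbon

Compound 4 carries the phenyl on the carbonyl carbon that compound 3 and compound 1 also carry, while it keeps the core of compound 2. Given that compound 1, compound 2 and compound 3 all fall within the scatter of one another, the step from compound 2 to compound 4 is expected to be small and not beyond the scatter, with no direction that can be asserted; the expected step is a 1.2-fold lower number from compound 2 to compound 4 (0.07 log units; within the scatter). For compound 4 the estimated value in this assay is 38000 nM, with a range of 15000 nM to 95000 nM.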

Compound 4, half-maximal inhibitory concentration: 38600 nM
Compound 4: middle estimate off by 1.0-fold (0.01 log units), on the low side, and the stated range covers the measured number.
By their numbers in this assay, from the lowest: compounds 1, 4, 3 and 2 (each within the scatter of the next).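

In this assay the series now has its first steps in one place: phenyl in place of butyl on a carbonyl carbon gives a 1.2-fold lower number from compound 2 to compound 4 (0.06 log units; within the scatter) and stays within the scatter, and amino in place of nitro on an aromatic carbon gives a 1.1-fold lower number from compound 3 to compound 4 (0.03 log units; within the scatter) and also stays within the scatter. With the core of compound 2 held fixed, the carbonyl carbon therefore takes either butyl or phenyl with no readable change in this read-out, and with the phenyl held fixed, the same is true of amino and nitro on the aromatic carbon. Nothing measured alongside these numbers speaks to why the steps are this small.

As far as these compounds go, both steps cover only these group pairs, so it remains open whether a different group on the carbonyl carbon, such as a longer chain or a chain ending in a carboxylic acid, would give a step beyond the scatter. From the compounds shown here alone, it also remains open whether another group on the aromatic carbon, such as a methoxy or a chlorine atom, would separate from amino and nitro on the shared core.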